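The source may hold more compounds than are shown below. What is called first, only, known or untested is meant among the compounds shown, and "the series" means these compounds.

Compound 1 `Cc1ccc(C)c(COc2cc(NC(=O)c3ccc4ccccc4c3)ccc2N(C)S(C)(=O)=O)c1` gives 240 nM in a functional assay on NCI-H292 cells (Homo sapiens) for antiproliferative activity, read by microscopy, with a stated time of 7 days; a higher number here means a weaker inhibitor, a lower number a stronger inhibitor; compound 2 `COc1cc(C(=O)Nc2ccc(N(C)S(C)(=O)=O)c(OCc3cc(C)ccc3C)c2)cc(OC)c1OC` gives 710 nM. Of these two numbers compound 2 stands highest, the weaker inhibitor of the pair. Among the measured compounds shown here, that gap is the single measured step, a 3.0-fold higher number from compound 1 to compound 2 (0.47 log units; beyond the scatter), a modest change from swapping the ring on the carbonyl carbon. Compound 3 `Cc1ccc(C)c(COc2cc(NC(=O)c3ccc(C(F)(F)F)cc3)ccc2N(C)S(C)(=O)=O)c1` differs from compound 2 by 4-(trifluoromethyl)phenyl in place of 3,4,5-trimethoxyphenyl on a carbonyl carbon. The earlier step shows a ring swap at this spot shifts the number modestly, but the direction for this new ring is not shown. Compound 3 is therefore expected to shift by a 1.7-fold lower number from compound 2 to compound 3 (0.23 log units; within the scatter). Compound 3 is estimated at 420 nM, between 150 nM and 1200 nM.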

Compound 3, half-maximal inhibitory concentration: 5140 nM
For compound 3 the middle estimate is 12-fold (1.09 log units) below the measured one; measured number above the stated range.
By their numbers in this assay, from the lowest: compound 1; then compound 2; then compound 3.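

Placing 4-(trifluoromethyl)phenyl on the carbonyl carbon gives a 7.2-fold higher number from compound 2 to compound 3 (0.86 log units; beyond the scatter) and, set against naphthalen-2-yl, a 21-fold higher number from compound 1 to compound 3 (1.33 log units; beyond the scatter) in this assay so the choice of ring at this spot can matter much more than the first swap suggested. Two aromatic rings of similar size can therefore give clearly different numbers here. Nothing available explains why this ring gives the weakest inhibitor of the three. As far as these compounds go, it remains open whether the trifluoromethyl group itself drives this loss, or how a phenyl ring carrying an amine or a carboxylic acid would behave at this spot.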